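The source may report more compounds than this note shows. Statements on the series, on what has been measured and on what is new or still open speak of the compounds shown alone.

In a functional assay on HeLa cells (Homo sapiens) for inhibition, read by CCK-8 assay, with a stated time of 48 h (a higher number here means a weaker inhibitor, a lower number a stronger inhibitor), compound 1 `COc1ccc(NC(=O)NCCNS(=O)(=O)c2ccc(-c3ccccc3OCc3ccccc3)s2)cc1` gives > 50000 nM, a limit and not a number. Compound 2 `COc1cccc(NC(=O)NCCNS(=O)(=O)c2ccc(-c3ccccc3OCc3ccccc3)s2)c1` gives > 50000 nM, also a limit. Compound 2 therefore stands at the limit of > 50000 nM in this assay, at which 2 of the 2 values shown sit, and a step that the two limits leave unreadable from compound 1 to compound 2 offers no size to carry forward. Compound 3 `O=[N+]([O-])c1ccc(NC(=S)NCCNS(=O)(=O)c2ccc(-c3ccccc3OCc3ccccc3)s2)cc1` swaps the (3-methoxyphenyl)carbamoyl group of compound 2, on an amine nitrogen: a group of 12 heavy atoms (7 carbon, 2 nitrogen, 2 oxygen, 1 sulfur; one six-membered aromatic ring of carbon only) in place of a group of 11 heavy atoms (8 carbon, 1 nitrogen, 2 oxygen; one six-membered aromatic ring of carbon only), on an amine nitrogen. Among the measured compounds shown here, no measured step covers this change, so only a small, uncertain strengthening in this assay is expected, and another limit remains quite possible. The expected change is an at least 1.2-fold lower number from compound 2 to compound 3 (0.09 log units; that floor lies within the scatter). For compound 3 the estimated value is 40000 nM, within an expected range of 12000 nM to 100000 nM.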

Compound 3, half-maximal inhibitory concentration: 7100 nM
The estimate for compound 3 lay 5.6-fold (0.75 log units) above the measured number; the whole stated range lies above it.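

Among the compounds shown here, changing the group on the amine nitrogen gives the first true number in this assay, with an at least 7.0-fold lower number from compound 2 to compound 3 (0.84 log units; beyond the scatter) and an at least 7.0-fold lower number from compound 1 to compound 3 (0.84 log units; beyond the scatter). Both steps are only minimum sizes, and the step between compound 1 and compound 2 cannot be read. Compound 1 and compound 2 both stay at a limit of the assay: the limit of > 50000 nM in this assay, at which 2 of the 3 values shown sit.

Compound 3 brings in both sulfur and a nitro group, so the compounds shown cannot separate the two. From the compounds shown here alone, how a nitrile or a carboxylic acid in place of that nitro group would read also remains open.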